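The compounds below may be only part of what the source reports. "The series", "measured", "known", "first", "only" and "open" are said of these compounds alone.

Measured so far in an ADME assay on S9 fraction from liver (Rattus norvegicus) for metabolic stability, with a stated time of 1 h; a higher number here means that more of the compound is left, a lower number that less of the compound is left:
compound 1 `N#Cc1cnc(NCc2cnccc2C(F)(F)F)cc1N[C@H]1C[C@@H](O)C1` gives 70%
compound 2 `N#Cc1cnc(NCc2ccccc2)cc1N[C@H]1CC[C@@H](O)CC1` gives 64%
compound 3 `N#Cc1cnc(NCc2cncnc2C(F)(F)F)cc1N[C@H]1CC[C@@H](O)CC1` gives 76%

Compound 3 (76%) sits at the upper end of these three numbers. Compound 1 (70%) lies within the usual scatter of it, so the two cannot be told apart, while compound 2 (64%) lies lower by more than the scatter.

The next compound to be tested is compound 4 `CC(C)(F)c1ncncc1CNc1cc(N[C@H]2CC[C@@H](O)CC2)c(C#N)cn1`, which keeps everything in compound 3 except for one group. On an aromatic carbon, 1-fluoro-1-methylethyl stands in place of trifluoromethyl (1-fluoro-1-methylethyl in place of trifluoromethyl on an aromatic carbon). Going by the values given here, no two measured compounds differ in only one place, so the numbers give no direct guide to this swap.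

Among the compounds with values here, the only indirect hint is compound 2, the one measured compound without fluorine, at 64% in this comparison. It differs from compound 3 in more than one place, so it is weak evidence and supports only a cautious lean downward.

The expected change is a number 10 percentage points lower from compound 3 to compound 4 (within the scatter) in this assay, a modest fall near the edge of the scatter. The estimated value for compound 4 is 66% with an expected range from 46% to 82% until the measurement is in.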

Compound 4, percent of the compound remaining: 81%
For compound 4 the middle estimate is 15 percentage points below the measured one, and the stated range covers the measured number.
By their numbers in this assay, from the lowest: compounds 2, 1, 3 and 4 (each within the scatter of the next, the first and the last beyond it).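

In this assay, putting 1-fluoro-1-methylethyl where trifluoromethyl stood gives a number 5 percentage points higher from compound 3 to compound 4 (within the scatter), so compound 3 and compound 4 cannot be told apart. Going by these compounds alone, this is the first pair here that differs in one place only, which makes it the first direct reading of this position, on an aromatic carbon of the six-membered aromatic ring with 2 nitrogen. It shows that, in this assay, the group at this position can go from three fluorine atoms on one carbon to one fluorine atom in a three-carbon group with no change that can be separated from the usual scatter, and nothing available explains why the two compounds read alike.

Left open is how this position would respond to a group with no fluorine at all, such as methyl or isopropyl, or to one carrying oxygen, such as methoxy. Also open, as far as these compounds go, is whether the same swap would read the same way on the core of compound 1, whose hydroxyl-bearing part differs from that of compound 3.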